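The source may hold more compounds than are shown below. What is called first, only, known or untested is meant among the compounds shown, and "the series" means these compounds.

Measured in an ADME assay on microsomes from liver (Homo sapiens) for metabolic stability; a higher number here means faster removal of the compound, a lower number slower removal:

- Compound 1 `CC(=O)N[C@@H]1CCC[C@H](C(=O)Nc2cc(-c3cnn4c3CCCC4)ccn2)C1`: < 3 mL.min-1.g-1
- Compound 2 `CC(=O)N[C@@H]1CCC[C@H](C(=O)Nc2cc(-c3cnn4c3CCC4)c(Cl)cn2)C1`: < 3 mL.min-1.g-1
- Compound 3 `CC(=O)N[C@@H]1CCC[C@H](C(=O)Nc2cc(-c3cnn4c3CC(C)(C)CC4)ccn2)C1`: 29 mL.min-1.g-1

Compound 2 stands at the limit of < 3 mL.min-1.g-1 in this assay, at which 2 of the 3 values shown sit. This reading is a limit of the assay and not a number. Compound 1 carries the same kind of limit. Compound 3 is the only one of the three with a true number in this assay, at 29 mL.min-1.g-1.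

The next compound to consider is compound 4 `CC(=O)N[C@@H]1CCC[C@H](C(=O)Nc2cc(-c3cnc4n3CC(C)(C)C4)c(Cl)cn2)C1`, which is made from compound 2 by exchanging one group: a group of 10 heavy atoms (8 carbon, 2 nitrogen; one five-membered non-aromatic ring with 1 hetero atom, one five-membered aromatic ring with 2 hetero atoms) in place of a group of 8 heavy atoms (6 carbon, 2 nitrogen; one five-membered non-aromatic ring with 1 hetero atom, one five-membered aromatic ring with 2 hetero atoms), on an aromatic carbon. The new group sits on the same aromatic carbon, ortho to the chloro group and opposite the ring nitrogen, and the rest of the molecule stays as it is.

Going by the values given here, no measured pair shows the size of this exchange directly, so any forecast is rough. Compound 3 gives 29 mL.min-1.g-1, which shows that a compound of this general shape can be removed at a measurable rate. The expected step of an at least 3.0-fold higher number from compound 2 to compound 4 (0.47 log units; beyond the scatter) is therefore upward and moderate, though compound 4 could still return only a limit. For compound 4 the estimated value is 9 mL.min-1.g-1, with an expected range from 3 mL.min-1.g-1 to 30 mL.min-1.g-1.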

Compound 4, intrinsic clearance in microsomes: 63 mL.min-1.g-1
Estimate against measurement, compound 4: 7.0-fold (0.85 log units) below; measured number outside the range, above it.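

In this assay the exchange on this aromatic carbon, ortho to the chloro group and opposite the ring nitrogen, gives an at least 21-fold higher number from compound 2 to compound 4 (1.32 log units; beyond the scatter) and is the only difference between the two compounds. As far as these compounds go, the true size of this step remains unknown because the reading for compound 2 is a limit of the assay and not a number: the limit of < 3 mL.min-1.g-1 in this assay, at which 2 of the 4 values shown sit. The position is therefore sensitive to the group it carries, even though the leaving and entering groups have the same kinds of rings, the same hydrogen-bond donor and acceptor counts and no net charge, and differ in having 8 and 10 heavy atoms and in how those atoms are arranged.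

The compounds shown do not separate the extra carbon atoms from the different arrangement of the atoms, so either could account for the step. A version of the entering group with a hydroxyl on its non-aromatic ring, or with fluorine atoms on that ring, would test whether the higher number follows from the added carbon atoms.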